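Toward a hexyloxy analogue in the cyclopropane nucleoside series

A few compounds are considered here, and "the series" means these few. Any claim that something is new, unique, unknown or untested is made for them only; others in the source may bear on it.

For the measured compounds named here, compound 1 `Nc1nc(NC2CC2)c2ncn(/C=C3/CC3(CO)CO)c2n1` is the only member of the set with a number in an ADME assay on BCBL1 cells (Homo sapiens) for cytotoxicity, with a stated time of 7 days; on this read-out higher numbers stand for lower toxicity in this test and lower numbers for higher toxicity in this test: compound 1 gives 71500 nM. Compound 2 `CCCCCOc1nc(N)nc2c1ncn2/C=C1/CC1(CO)CO` carries a pentyloxy group in the same position. In this assay compound 2 reaches only a limit, > 20000 nM. Compound 3 `Nc1nc(N2CCCC2)c2ncn(/C=C3/CC3(CO)CO)c2n1` carries a pyrrolidin-1-yl group there. In this assay compound 3 likewise sits at a limit, > 20000 nM. The step from compound 1 to compound 2 is therefore a step that the limit leaves unreadable from compound 1 to compound 2, the step from compound 1 to compound 3 is a step that the limit leaves unreadable from compound 1 to compound 3, and the step from compound 2 to compound 3 is a step that the two limits leave unreadable from compound 2 to compound 3; this follows from the limit of > 20000 nM in this assay, at which 2 of the 3 values shown sit.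

Compound 4 `CCCCCCOc1nc(N)nc2c1ncn2/C=C1/CC1(CO)CO` is the next member to be measured. Its change from compound 1 is hexyloxy in place of cyclopropylamino on an aromatic carbon. Going by the values given here, the nearest measured step is the one from compound 1 to compound 2, a pentyloxy chain one carbon shorter, which the limit of > 20000 nM in this assay, at which 2 of the 3 values shown sit, leaves unreadable in size. The expectation for compound 4 is therefore a step in this assay of no readable direction from compound 1, and a fair chance that compound 4 also returns only a limit. Compound 4 is estimated at 50000 nM, between 15000 nM and 150000 nM, which would be a step of a 1.4-fold lower number from compound 1 to compound 4 (0.16 log units; within the scatter).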

Compound 4, half-maximal cytotoxic concentration: > 20000 nM
Compound 4 gave a limit, no number (the forecaster's own chance of this, stated with the estimate: 60%); the middle value is on the limit's open side.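

Compound 4 returns only a limit in this assay, > 20000 nM, so its steps from compound 1, compound 2 and compound 3 cannot be read, and the cause is this: the limit of > 20000 nM in this assay, at which 3 of the 4 values shown sit.

The compounds shown leave open whether compound 2, compound 3 and compound 4 differ from one another or from compound 1 in this assay.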